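The compounds below may be only part of what the source reports. "The series", "measured", "known", "first", "only" and "open" are said of these compounds alone.

Compound 1 `CC(C)C(Cc1nnc[nH]1)c1ccc(-c2ccc3cccc(F)c3c2)[nH]c1=O` gives 17 nM in a functional assay on CHO cells for antagonist activity at prostaglandin E2 receptor EP3 subtype (Homo sapiens), read by cAMP accumulation; a lower number here means a stronger inhibitor, a higher number a weaker inhibitor. Its companion, compound 2 `CCC(CC)(c1nnc[nH]1)c1ccc(-c2ccc3cccc(F)c3c2)[nH]c1=O`, gives 36 nM in this assay, so compound 1 carries the lower of the two numbers, a gap that lies beyond the usual scatter. Compound 3 `CC(C)C(Nc1nccs1)c1ccc(-c2ccc3cccc(F)c3c2)[nH]c1=O` changes compound 1 in one place: (1,3-thiazol-2-yl)amino in place of (4H-1,2,4-triazol-3-yl)methyl on a saturated chain carbon bound to an aromatic carbon and a saturated chain carbon. Going by the values given here, no measured pair shows this exchange, so the expectation rests on the shared core alone. A step in the weakening direction, estimated as a 3.5-fold higher number from compound 1 to compound 3 (0.55 log units; beyond the scatter), seems most likely. For compound 3 the estimated value is 60 nM, within a range from 15 nM to 300 nM.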

Compound 3, half-maximal inhibitory concentration: 10 nM
Compound 3: middle estimate off by 6.0-fold (0.78 log units), on the high side, and the stated range ends above it.
By their numbers in this assay, from the lowest: compounds 3 and 1 (each within the scatter of the next); then compound 2.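

On the saturated chain carbon bound to an aromatic carbon and a saturated chain carbon, (1,3-thiazol-2-yl)amino can replace (4H-1,2,4-triazol-3-yl)methyl with a 1.7-fold lower number from compound 1 to compound 3 (0.23 log units; within the scatter) in this assay, so the two compounds cannot be told apart here. This place therefore accepts more than the triazole group: a ring containing sulfur, attached through an amino nitrogen, also fits. Nothing available explains this tolerance. From the compounds shown here alone, whether any ring is needed at this carbon remains open. A plain amine or a carboxylic acid in the same place would address that question.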